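A few compounds are considered here, and "the series" means these few. Any claim that something is new, unique, unknown or untested is made for them only; others in the source may bear on it.

Working notes on the trimethoxyphenyl amide series.

Compound 1 `C=C(C)C(=O)N(Cc1ccc(OC)c(O)c1)c1cc(OC)c(OC)c(OC)c1` is the reference point. In a functional assay on KYSE-450 cells (Homo sapiens) for inhibition, read by MTT assay, with a stated time of 48 h (a lower number here means a stronger inhibitor, a higher number a weaker inhibitor), compound 1 gives 200 nM, the lowest of the two numbers recorded; the nearest neighbour is compound 2 `C/C=C/C(=O)N(Cc1ccc(OC)c(Br)c1)c1cc(OC)c(OC)c(OC)c1`, which in this assay gives 10500 nM, a gap beyond the scatter. Compound 3 `COc1cc(NCc2ccc(C)cc2)cc(OC)c1OC` sits at the limit of this assay, > 80000 nM, so for compound 3 only a limit and no number is known (the limit of > 80000 nM in this assay, at which 1 of the 3 values shown sits). Within the data shown here, no pair among the measured compounds differs in a single place, so no measured step is available to calibrate the change below.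

The next compound, compound 4 `COc1ccc(CN(C(=O)CBr)c2cc(OC)c(OC)c(OC)c2)cc1O`, differs from compound 1 in one place: bromomethyl in place of 1-methylethenyl on a carbonyl carbon. The amide, the benzyl group bearing methoxy and hydroxy, and the shared core are unchanged.

Expectation. The acrylamide of compound 1 and the bromoacetamide of compound 4 both keep the reactive acyl position intact, and no shown value speaks against activity of the bromoacetamide. For compound 4 in this assay the expected value is 150 nM, with a range from 30 nM to 800 nM. The estimated step of a 1.3-fold lower number from compound 1 to compound 4 (0.12 log units; within the scatter) is expected to be small, not beyond the scatter, with a slight lean to a lower number.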

Compound 4, half-maximal inhibitory concentration: 120 nM
Compound 4: middle estimate off by 1.3-fold (0.10 log units), on the high side, and the stated range covers the measured number.
By their numbers in this assay, from the lowest: compounds 4 and 1 (each within the scatter of the next); then compound 2. At a limit, above all of these: compound 3.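

In this assay the step reads a 1.7-fold lower number from compound 1 to compound 4 (0.22 log units; within the scatter), so on this carbonyl carbon, whose other neighbour is the amide-type nitrogen, bromomethyl and 1-methylethenyl cannot be told apart. Among these compounds, this is the first measured change that sits in one place only, and it gives the position a calibration that compound 2 and compound 3 could not provide. It also shows that, in this one pair, the double bond of 1-methylethenyl is not required for a value at the level of compound 1, although nothing measured here bears on why the two groups read alike.

On these data alone, whether a chloromethyl group, a plain methyl group, a dimethylaminomethyl group or a longer chain on the same carbonyl carbon would read alike remains open. Compound 2 and compound 3 each differ from compound 1 in more than one place, so what separates them from compound 1 and compound 4 stays unassigned, including any contribution from the hydroxy group of the benzyl group.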